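Ring swap on the fused bicycle: compound 2 to compound 3

A few compounds are considered here, and "the series" means these few. Any claim that something is new, unique, unknown or untested is made for them only; others in the source may bear on it.

Measured compounds in an assay on CHO cells for agonist activity at Glucose-dependent insulinotropic receptor (Homo sapiens), read by a luciferase reporter and cAMP accumulation, with a stated time of 2 h; a lower number here means that less compound is needed, a higher number that more compound is needed for the effect: compound 1 `CC(=O)N(C)c1ccc2c(c1)CCN2c1cc(OC2CCN(c3nc(C(C)C)no3)CC2)ncn1` gives 75 nM; compound 2 `CC(C)c1noc(N2CCC(Oc3cc(N4CCc5cc(N6CCCC6=O)ccc54)ncn3)CC2)n1` gives 33 nM.

Compound 2 stands lowest of the two numbers in this assay; its nearest neighbour is compound 1, with the step of a 2.3-fold lower number from compound 1 to compound 2 (0.36 log units; beyond the scatter) lying beyond the scatter. Compound 3 `CC(C)c1noc(N2CCC(Oc3cc(N4CCc5cc(N6CCCNS6(=O)=O)ccc54)ncn3)CC2)n1` differs from compound 2 by a group of 8 heavy atoms (3 carbon, 2 nitrogen, 2 oxygen, 1 sulfur; one six-membered non-aromatic ring with 3 hetero atoms) in place of a group of 6 heavy atoms (4 carbon, 1 nitrogen, 1 oxygen; one five-membered non-aromatic ring with 1 hetero atom), on an aromatic carbon. Going by the values given here, only one measured step bears on this position, a 2.3-fold lower number from compound 1 to compound 2 (0.36 log units; beyond the scatter), and it involves a different entering group, so it shows the position tolerates a change of this kind but does not fix the direction. A modest step at most is expected, a 1.4-fold higher number from compound 2 to compound 3 (0.13 log units; within the scatter), with wide uncertainty. Compound 3 is therefore estimated at 45 nM, between 15 nM and 140 nM.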

Compound 3, half-maximal effective concentration: 24 nM
Estimate against measurement, compound 3: 1.9-fold (0.27 log units) above; measured number inside the range.
By their numbers in this assay, from the lowest: compounds 3 and 2 (each within the scatter of the next); then compound 1.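

With a 1.4-fold lower number from compound 2 to compound 3 (0.14 log units; within the scatter) in this assay, this aromatic carbon accepts the group of 8 heavy atoms, with its six-membered ring and hydrogen-bond donor, as readily as 2-oxopyrrolidin-1-yl. Against the acetyl(methyl)amino compound the same group gives a 3.1-fold lower number from compound 1 to compound 3 (0.49 log units; beyond the scatter) and so extends the tolerance seen earlier to a ring with 3 hetero atoms. No measurement bears on the reason for either step.

Still open, on these data alone, is whether a morpholine or an open-chain sulfonamide on this carbon would keep the number. As far as these compounds go, the part played by the hydrogen-bond donor of the entering group also remains open.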